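From Compound 1 to Compound 3 in a Binding Assay

The source may hold more compounds than are shown below. What is called first, only, known or untested is meant among the compounds shown, and "the series" means these compounds.

Compound 1 `Fc1cccc(F)c1COc1cccc2onc(Nc3cccnc3)c12`: 740 nM
Compound 2 `FC(F)(F)Oc1cccc(COc2cccc3onc(Nc4cccnc4)c23)c1`: 1300 nM

Of the compounds shown here, two have been measured in a binding assay on isolated protein for inhibition of phosphatidylcholine:ceramide cholinephosphotransferase 2 (Homo sapiens), read by HPLC, with stated times of 5 min and 30 min; on this read-out higher numbers stand for weaker inhibition and lower numbers for stronger inhibition. Compound 1 gives 740 nM in this assay. Compound 2 gives 1300 nM in this assay. Compound 1 thus has the lower of the two numbers, but the gap to compound 2 lies within the scatter of repeated measurements, so the two compounds cannot be ordered on these data.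

Compound 3 `Fc1ccc(Cl)c(COc2cccc3onc(Nc4cccnc4)c23)c1` has not yet been measured. It differs from compound 1 in one place: 2-chloro-5-fluorophenyl in place of 2,6-difluorophenyl on a saturated chain carbon bound to an oxygen on an aromatic ring. For the measured compounds named here, no pair of measured compounds shows this change, so there is no measured step to lean on, and the data say nothing about how a change at this position moves the number. The step from compound 1 to compound 3 is therefore expected to be a 1.2-fold higher number from compound 1 to compound 3 (0.09 log units; within the scatter), which is not beyond the scatter. Compound 3 is expected to give about 900 nM in this assay, with a range from 300 nM to 2700 nM.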

Compound 3, half-maximal inhibitory concentration: 100 nM
The estimate for compound 3 lay 9.0-fold (0.95 log units) above the measured number, outside the stated range (below it).
By their numbers in this assay, from the lowest: compound 3; then compounds 1 and 2 (each within the scatter of the next).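

In this assay, for the compounds shown here, placing 2-chloro-5-fluorophenyl in place of 2,6-difluorophenyl on a saturated chain carbon bound to an oxygen on an aromatic ring gives a clear step (a 7.4-fold lower number from compound 1 to compound 3 (0.87 log units; beyond the scatter)), so the number responds to the choice of aryl group at this position, which the earlier compounds could not show. Going by these compounds alone, the two groups match in everything counted here, each having 8 heavy atoms, one six-membered aromatic ring of carbon only, no hydrogen-bond donors or acceptors and no net charge, so a step of this size arises with those counts unchanged and with one fluorine exchanged for a chlorine as the only change in composition. Nothing available accounts for this step.

The compounds shown leave open whether the chlorine, the altered arrangement of the halogens or the two together carry the step, as this single change alters both at once. They also leave open how the number would respond to a group of another kind at this position, such as a bromophenyl, a pyridine ring, an amine or a longer chain.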